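The compounds below may be only part of what the source reports. "The series", "measured", "known", "first", "only" and "open" are said of these compounds alone.

In an in vitro ADME assay on microsomes from liver (Rattus norvegicus) for metabolic stability (a lower number here means that the compound disappears faster, a higher number that the compound lasts longer), compound 1 `CC(CNC(=O)c1ccc(F)cc1)CN(C1=NS(=O)(=O)c2ccccc21)c1ccccc1` gives 0.367 h. Compound 2 `CC(C)(CNC(=O)c1cccc(C(F)(F)F)c1)CN(C1=NS(=O)(=O)c2ccccc21)c1ccccc1` gives < 0.25 h, which is a limit of the assay and not a number. Compound 2 therefore stands at the limit of < 0.25 h in this assay, at which 1 of the 2 values shown sits. Compound 3 `CC(C)(CNC(=O)c1cccc(C(F)(F)F)c1)CN(C1=NS(=O)(=O)c2cc(F)ccc21)c1ccccc1` differs from compound 2 by fluoro in place of hydrogen on an aromatic carbon. Among the compounds with values here, no measured pair of compounds shows this change, so only a small shift in this assay is expected, with no firm direction. The expected change is small a step that the limit leaves unreadable from compound 2 to compound 3. For compound 3 the estimated half-life is 0.22 h, expected to fall between 0.12 h and 0.4 h.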

Compound 3, half-life: 0.65 h
Estimate against measurement, compound 3: 3.0-fold (0.47 log units) below; the measured number lies above the stated range.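

In this assay, within the data shown here, fluoro in place of hydrogen on an aromatic carbon, meta to a fused ring and para to a fused ring, gives an at least 2.6-fold higher number from compound 2 to compound 3 (0.41 log units; beyond the scatter), which is the first reading of this change at this position. The step has only a lower bound, and its true size cannot be read, because compound 2 stands at a limit and not at a number: the limit of < 0.25 h in this assay, at which 1 of the 3 values shown sits.

From the compounds shown here alone, whether a chloro, nitrile or methoxy group on the same carbon would give a similar step remains open. So does whether fluoro there would do the same in compound 1.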